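From compound 3 to compound 4: a sulfo swap

The source may hold more compounds than are shown below. What is called first, only, known or untested is meant among the compounds shown, and "the series" means these compounds.

Three compounds on a shared core have been taken to an ADME assay on MDCK cells (Canis lupus familiaris) for cytotoxicity, with a stated time of 48 h (on this read-out higher numbers stand for lower toxicity in this test and lower numbers for higher toxicity in this test), with little to show for it. Compound 1 (`CCC(CC)O[C@@H]1C=C(S(=O)(=O)CCc2ccncc2)C[C@H](N)[C@H]1NC(C)=O`) has no result here ("not determined" (no result reported)). Compound 2 (`CCC(CC)O[C@@H]1C=C(S(C)(=O)=O)C[C@H](N)[C@H]1NC(C)=O`) likewise has none ("not determined" (no result reported)). Compound 3 (`CCC(CC)O[C@@H]1C=C([S+]([O-])O)C[C@H](N)[C@H]1NC(C)=O`) is reported only as a limit and not as a number (> 100000 nM). That single reading is all the series offers so far (the limit of > 100000 nM in this assay, at which 1 of the 3 values shown sits).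

In this assay compound 4 (`CCC(CC)O[C@@H]1C=C(S(=O)(=O)O)C[C@H](N)[C@H]1NC(C)=O`) is still to be measured. It departs from compound 3 in one place, on a double-bonded ring carbon, where a sulfo group enters (a group of 4 heavy atoms (3 oxygen, 1 sulfur; no ring) in place of a group of 3 heavy atoms (2 oxygen, 1 sulfur; no ring), on a double-bonded ring carbon). Among the compounds with values here, no measured step sizes such a change. The expectation rests only on the limit of compound 3 (> 100000 nM). The step expected is none beyond the usual scatter, with no direction favoured (a number no higher from compound 3 to compound 4 (the limit leaves the size open)). Compound 4 is estimated at 100000 nM with an expected range from 50000 nM to 200000 nM and may well return only a limit.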

Compound 4, half-maximal cytotoxic concentration: > 100000 nM
Compound 4: no number, only a limit; the forecaster's own chance of this, stated with the estimate: 90%; the middle value sits exactly at the limit.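

Compound 3 and compound 4 each give only a limit in this assay, and the step between them cannot be read: the limit of > 100000 nM in this assay, at which 2 of the 4 values shown sit.

The compounds shown leave open where the true value of either compound lies, and whether the sulfo group of compound 4 changes the half-maximal cytotoxic concentration at all.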